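The source may hold more compounds than are shown below. What is called first, only, known or untested is meant among the compounds shown, and "the series" means these compounds.

Working notes on the series. Compound 1 `Cc1cccc(C(=O)N(C(=S)OCCN2C(=O)c3ccccc3C2=O)c2ccc(Cl)cc2)c1` is the reference here. Within the data shown here, in an ADME assay on MT4 cells (Homo sapiens) for cytotoxicity, read by MTT assay (on this read-out higher numbers stand for lower toxicity in this test and lower numbers for higher toxicity in this test), compound 1 gives 58000 nM, the higher of the two numbers so far; compound 2 `O=C1c2ccccc2C(=O)N1CCOC(=S)N(C(=O)c1ccc(Cl)c(Cl)c1)c1ccccc1` gives 52000 nM, and the gap between the two lies within the scatter, so neither can be set apart from the other.

Compound 3 `O=C1c2ccccc2C(=O)N1CCOC(=S)N(C(=O)c1c(Cl)cccc1Cl)c1ccc(Cl)cc1` differs from compound 1 in one place: 2,6-dichlorophenyl in place of 3-methylphenyl on a carbonyl carbon. Among the measured compounds shown here, no step of this kind has been measured. The expected step from compound 1 to compound 3 in this assay is a 1.3-fold lower number from compound 1 to compound 3 (0.11 log units; within the scatter), a change not expected to exceed the scatter in either direction. Compound 3 is therefore estimated at 45000 nM, with a range from 20000 nM to 110000 nM.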

Compound 3, half-maximal cytotoxic concentration: 20000 nM
The estimate for compound 3 lay 2.3-fold (0.35 log units) above the measured number; measured number inside the range.
By their numbers in this assay, from the lowest: compound 3; then compounds 2 and 1 (each within the scatter of the next).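

With 2,6-dichlorophenyl in place of 3-methylphenyl on a carbonyl carbon, the series shows its first step beyond the scatter in this assay: a 2.9-fold lower number from compound 1 to compound 3 (0.46 log units; beyond the scatter), a modest move towards higher toxicity in this test. This place on the core of compound 1 therefore responds to a change of group, which the pair of compounds 1 and 2 could not show. Nothing measured accounts for this step. Still open, from the compounds shown here alone, is how a single-chlorine group such as 2-chlorophenyl, or a pyridyl or aminophenyl group, would read at this place.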